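The compounds below may be only part of what the source reports. "The series", "measured", "known", "first", "only" and "open" are said of these compounds alone.

For the measured compounds named here, compound 1, `O=C(COc1cccc2ccccc12)N/N=C/c1ccc(O)cc1`, is one of two compounds measured in a physicochemical assay for lipophilicity, measured as octanol-water partition; on this read-out lower numbers stand for lower lipophilicity and higher numbers for higher lipophilicity. In this assay compound 1 gives 3.73, the higher of the two numbers. Compound 2, `C/C(=N\NC(=O)COc1cccc2ccccc12)c1ccccc1O`, gives 3.08 in this assay, which is lower than compound 1 by an amount beyond the usual scatter of the measurement.

The step of interest leads from compound 1 to compound 3, `O=C(COc1cccc2ccccc12)N/N=C/c1ccccc1`, which has not yet been measured. The change is hydrogen in place of hydroxy on an aromatic carbon, on an aromatic carbon of a six-membered aromatic ring of carbon only. Going by the values given here, since no measured pair here shows this change, the expectation rests on the nature of the change itself: a hydroxy group leaves and a hydrogen enters, and the step in this assay is expected to be upward and of a size beyond the scatter, namely a number 0.57 log units higher from compound 1 to compound 3 (beyond the scatter). Compound 3 is therefore estimated at 4.3, within a range from 3.9 to 4.7.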

Compound 3, partition coefficient: 4.02
For compound 3 the middle estimate is 0.28 log units above the measured one, within the range that was stated.
By their numbers in this assay, from the lowest: compound 2; then compounds 1 and 3 (each within the scatter of the next).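

In this assay, the change from 4-hydroxyphenyl to phenyl gives a number 0.29 log units higher from compound 1 to compound 3 (within the scatter), the only reading of this change among the compounds shown. For the compounds shown here, at this place, on an aromatic carbon of a six-membered aromatic ring of carbon only and para to a large group, hydrogen in place of hydroxy therefore gives no step that this measurement can distinguish from the scatter. No measured evidence bears on this result.

On these data alone, whether an amine, a methoxy group or a carboxylic acid at the same place would give a step beyond the scatter remains open. Going by these compounds alone, also open is whether hydrogen in place of hydroxy would read the same way on a different core, as this single pair is the only instance of the change.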